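Swapping an Aryl Group in an Inactive Bis-amide Series

The compounds below may be only part of what the source reports. "The series", "measured", "known", "first", "only" and "open" are said of these compounds alone.

Compound 1 `COc1ccccc1C(=O)Nc1cccc(NC(=O)c2ccc(Cl)c(Cl)c2)c1` is the reference point. In an in vitro functional assay on HEK293-A cells for antagonist activity at metabotropic glutamate receptor 5 (Rattus norvegicus), read by calcium flux (on this read-out lower numbers stand for stronger inhibition and higher numbers for weaker inhibition), compound 1 gives only a limit, > 30000 nM. Compound 2 `COc1ccccc1C(=O)Nc1cccc(NC(=O)c2ccco2)c1` likewise reaches only a limit in this assay, > 30000 nM. Compound 3 `COc1ccccc1C(=O)Nc1cccc(NC(=O)C2CC2)c1` is the third member, and in this assay compound 3 also stops at a limit, > 30000 nM. Because of the limit of > 30000 nM in this assay, at which 3 of the 3 values shown sit, none of the three steps among them can be sized: a step that the two limits leave unreadable from compound 1 to compound 2, a step that the two limits leave unreadable from compound 1 to compound 3 and a step that the two limits leave unreadable from compound 2 to compound 3 all stay unread.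

Compound 4 `O=C(Nc1cccc(NC(=O)c2ccc(Cl)c(Cl)c2)c1)c1cccc(Cl)c1` changes the other amide of compound 1: 3-chlorophenyl in place of 2-methoxyphenyl on a carbonyl carbon. Within the data shown here, no measured step touches this side of the shared core, so the three unreadable steps give no direction for it. Compound 4 is therefore expected to sit near the limit as well, estimated at 30000 nM with a range of 8000 nM to 100000 nM, which amounts to an expected step of a number no higher from compound 1 to compound 4 (the limit leaves the size open).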

Compound 4, half-maximal inhibitory concentration: > 30000 nM
Compound 4: a limit, no number (the forecaster's own chance of this, stated with the estimate: 70%); the middle value sits exactly at the limit.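

Compound 4, like compound 1, gives only a limit, so no size can be read for the step between them, because of this shared bound: the limit of > 30000 nM in this assay, at which 4 of the 4 values shown sit. The compounds shown leave open whether any change at either amide gives a measurable value in this assay at all.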